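This account rests on a few compounds, and the source may have more. Where it says the series, first, only, none or still open, it means among the compounds named here.

The series is assessed in a functional assay on HCC827 cells (Homo sapiens) for inhibition, read by fluorescence and resazurin assay, with a stated time of 72 h; a lower number here means a stronger inhibitor of growth, a higher number a weaker inhibitor of growth. Compound 1 `NCCCCNc1nc(Nc2ccc(Oc3nccs3)cc2)c2ncn(C3CCCC3)c2n1` gives 6310 nM in this assay, and compound 2 `OCCCCNc1nc(Nc2ccc(Oc3nccs3)cc2)c2ncn(C3CCCC3)c2n1` gives 6050 nM. The two differ by hydroxy in place of amino on a saturated chain carbon, four bonds along the chain from a nitrogen on an aromatic ring, a change that produced a 1.0-fold lower number from compound 1 to compound 2 (0.02 log units; within the scatter). Compound 3 `NCCCCNc1nc(Nc2ccc(N3CCN(Cc4ccccc4)CC3)cc2)c2ncn(C3CCC(O)C3)c2n1` gives 2290 nM in this assay, the lowest of the three numbers, with its gap to compound 2 and its gap to compound 1 both lying beyond the scatter. How the core of compound 3 differs from the core of compound 1 is not broken down here. Compound 4 `OCCCCNc1nc(Nc2ccc(N3CCN(Cc4ccccc4)CC3)cc2)c2ncn(C3CCC(O)C3)c2n1` has not yet been measured; it differs from compound 3 by hydroxy in place of amino on a saturated chain carbon, four bonds along the chain from a nitrogen on an aromatic ring, the same change that separates compound 1 from compound 2, made at the same place. Because the step of a 1.0-fold lower number from compound 1 to compound 2 (0.02 log units; within the scatter) stayed within the scatter, a step of similar size is expected here, namely a 1.0-fold higher number from compound 3 to compound 4 (0.00 log units; within the scatter). Compound 4 is therefore expected to land in this assay at 2300 nM, within a range from 1100 nM to 4800 nM, close to where compound 3 stands.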

Compound 4, concentration for 50% growth inhibition: 3960 nM
Compound 4: the middle estimate sits 1.7-fold (0.24 log units) below what was measured, and the stated range covers the measured number.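

Hydroxy in place of amino on this chain carbon gave a 1.7-fold higher number from compound 3 to compound 4 (0.24 log units; within the scatter) in this assay, and this step and the earlier one do not differ beyond the scatter: the same change on two cores in this assay, a 1.0-fold lower number (0.02 log units; within the scatter) from compound 1 to compound 2 and a 1.7-fold higher number (0.24 log units; within the scatter) from compound 3 to compound 4, 1.8-fold (0.26 log units) apart, within the scatter of two such steps. On the two cores shown, the change therefore carried over from the core of compound 1 to the core of compound 3 without a difference that can be told from the scatter, and neither step lies beyond the scatter on its own. Going by these compounds alone, this rests on only two pairs in a single assay, so it does not show that the change would behave alike on any other core, and it says nothing about how the two cores compare with each other.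

The compounds shown leave open whether other groups at the end of this chain, such as a carboxylic acid, a methoxy group or a dimethylamino group, would stand with amino and hydroxy. They also leave open whether a longer or shorter chain would carry the same change in the same way.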